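The compounds below may be only part of what the source reports. "The series", "measured", "known", "first", "only" and "open" are said of these compounds alone.

For the measured compounds named here, in a functional assay on the whole organism (B cells) with Mus musculus as the target (on this read-out lower numbers stand for smaller maximal responses and higher numbers for larger maximal responses), compound 1 `COc1ccc(Cn2c(=O)n(C3OC(CO)[C@@H](O)[C@H]3O)c3nc(N)nc(O)c32)cc1` gives 44%, the lower of the two numbers measured so far. Going by the values given here, the only other compound with a result here is compound 2 `Cn1c(=O)n([C@@H]2O[C@H](CO)[C@H]3OC(C)(C)O[C@H]32)c2nc(N)nc(O)c21`, which in this assay gives 193%, a reading that lies beyond the usual scatter above that of compound 1. The two differ in several places at once, so their values show only where each stands, not what any single change does.

Compound 3 `Nc1nc(O)c2c(n1)n(C1OC(CO)[C@@H](O)[C@H]1O)c(=O)n2Cc1ccccc1` has not been measured. It differs from compound 1 in one place: hydrogen in place of methoxy on an aromatic carbon.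

Among the compounds with values here, no pair of measured compounds differs in a single place, so nothing measured tells how a change of this kind moves the response. The change is small, and the expected step from compound 1 to compound 3 is a number 6 percentage points higher from compound 1 to compound 3 (within the scatter), within the scatter or slightly beyond it, in either direction. For compound 3 the estimated value in this assay is 50%, with a likely range from 25% to 110%.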

Compound 3, largest response reached (reported as maximal response), in percent of the reference or control that the assay uses: 110%
Compound 3: middle estimate off by 60 percentage points, on the low side; the measured number falls inside the stated range.
By their numbers in this assay, from the lowest: compound 1; then compound 3; then compound 2.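

In this assay, replacing the methoxy of the 4-methoxybenzyl group with hydrogen, which leaves a plain benzyl, gives a number 66 percentage points higher from compound 1 to compound 3 (beyond the scatter). For the compounds shown here, this is the first single-place comparison, and it shows that this spot on the aromatic ring, para to a large group, is far from silent: a small edit moves the maximal response by a wide margin, and the compound without the methoxy gives the larger response. No available measurement explains the direction or size of this step.

On these data alone, with only hydrogen and methoxy to compare, it remains open whether other groups here would raise or lower the response. As far as these compounds go, a fluorine, a methyl or an amine at the same place could begin to answer that, and whether the step carries over to other parts of the series also remains unknown.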